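The source may report more compounds than this note shows. Statements on the series, on what has been measured and on what is new or still open speak of the compounds shown alone.

Working notes on the series. Compound 1 `CCCC(Oc1ccc(-n2cc(C(=O)N(C)C)cn2)cc1)c1ccc(C(=O)NCCC(=O)O)cc1`, compound 2 `CCC(Oc1ccc(-n2cc(C(F)(F)F)cn2)cc1)c1ccc(C(=O)NCCC(=O)O)cc1` and compound 3 `CCCC(Oc1ccc(-n2cc(C)cn2)cc1)c1ccc(C(=O)NCCC(=O)O)cc1` share one core and differ in the substituent on the aromatic carbon and in the chain at the ether carbon. In a functional assay on cells for antagonist activity at Glucagon receptor (Homo sapiens), read by cAMP accumulation, in the presence of a further agent that is not named here (on this read-out higher numbers stand for weaker inhibition and lower numbers for stronger inhibition), compound 1 gives > 30000 nM, which is a limit of the assay and not a number. In this assay compound 3 gives 11000 nM. Among the measured compounds shown here, the single measured step, an at least 2.7-fold lower number from compound 1 to compound 3 (0.43 log units; beyond the scatter), concerns the aromatic substituent only and says nothing about the chain.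

Compound 2 stands at a limit as well: in this assay compound 2 gives > 22000 nM, a limit of the assay (the limit of > 22000 nM in this assay, at which 1 of the 3 values shown sits), so only a bound is known for it.

Compound 4 `CC(C)CC(Oc1ccc(-n2cc(C(F)(F)F)cn2)cc1)c1ccc(C(=O)NCCC(=O)O)cc1` differs from compound 2 in one place: isopropyl in place of methyl on a saturated chain carbon, two bonds along the chain from an aromatic carbon and an oxygen on an aromatic ring. For the measured compounds named here, no measured step bears on a change of this kind, since an at least 2.7-fold lower number from compound 1 to compound 3 (0.43 log units; beyond the scatter) sits at a different place. For this assay no step beyond the scatter is therefore expected, with the step from compound 2 to compound 4 estimated as a number no higher from compound 2 to compound 4 (the limit leaves the size open). Compound 4 is expected to give about 22000 nM, estimated range 7000 nM to 70000 nM, most likely again reported as a limit.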

Compound 4, antagonist equilibrium constant: 3400 nM
Beside the measured number, compound 4's estimate is 6.5-fold (0.81 log units) above it, and the stated range ends above it.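

With the trifluoromethyl group held fixed, isopropyl in place of methyl on this saturated chain carbon gives, in this assay, an at least 6.4-fold lower number from compound 2 to compound 4 (0.81 log units; beyond the scatter). Among the compounds shown here, this is the first measured step at the chain on the ether carbon, since the earlier step concerned only the aromatic substituent, and it shows that this position is not indifferent to the group it carries. The full size of the step stays open, because compound 2 stands at a limit of the assay and not at a number: the limit of > 22000 nM in this assay, at which 1 of the 4 values shown sits.

Going by these compounds, it remains open whether the step from ethyl to isobutyl would hold with methyl or dimethylcarbamoyl on the aromatic carbon in place of trifluoromethyl. Also open, on these data alone, is how this position would respond to a longer unbranched chain, a cyclopropyl ring or an amine on the chain.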